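Chain length at the ring nitrogen: compound 3 to compound 4

The compounds below may be only part of what the source reports. "The series", "measured", "known", "first", "only" and "open" are said of these compounds alone.

Measured so far:
compound 1, `CC(C)CN1CCc2c(sc(NC(=O)Nc3ccc(Cl)cc3)c2C(N)=O)C1`, 4510 nM
compound 2, `CC(C)(C)CN1CCc2c(sc(NC(=O)Nc3ccc(Cl)cc3)c2C(N)=O)C1`, 5560 nM
compound 3, `CN1CCc2c(sc(NC(=O)Nc3ccc(Cl)cc3)c2C(N)=O)C1`, 4700 nM

Of the compounds shown here, three sharing one core have been tested in a functional assay (strain AB) with Danio rerio as the target, read by microscopy, with a stated time of 1 h; a higher number here means that more compound is needed for the effect, a lower number that less compound is needed. They differ only in the group on the saturated chain carbon bound to the amine nitrogen in the ring. Compound 3 sits within the scatter of both neighbours: the step of a 1.0-fold higher number from compound 1 to compound 3 (0.02 log units; within the scatter) and the step of a 1.2-fold lower number from compound 2 to compound 3 (0.07 log units; within the scatter) are each within the scatter, as is the step of a 1.2-fold higher number from compound 1 to compound 2 (0.09 log units; within the scatter) between the other two. The numbers shown therefore give no sign that this position moves the half-maximal effective concentration at all.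

Compound 4, `CCCN1CCc2c(sc(NC(=O)Nc3ccc(Cl)cc3)c2C(N)=O)C1`, has not yet been measured in this assay. The change from compound 3 is ethyl in place of hydrogen on a saturated chain carbon bound to an amine nitrogen in a ring. Among the compounds with values here, the steps that bear on it are those that put or remove isopropyl and tert-butyl at the same place, and both were within the scatter. Adding ethyl at that place is therefore expected to leave the number within the scatter as well, with no direction favoured. For compound 4 the expected value in this assay is 4800 nM, within a range of 2400 nM to 9600 nM, which means an expected step of a 1.0-fold higher number from compound 3 to compound 4 (0.01 log units; within the scatter).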

Compound 4, half-maximal effective concentration: 3500 nM
Beside the measured number, compound 4's estimate is 1.4-fold (0.14 log units) above it; the range from low to high includes it.
By their numbers in this assay, from the lowest: compounds 4, 1, 3 and 2 (each within the scatter of the next).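

Compound 4 adds a straight chain to a set that previously held only methyl and the branched groups at this place, and the change from methyl to propyl, a 1.3-fold lower number from compound 3 to compound 4 (0.13 log units; within the scatter), leaves this assay without a step beyond the scatter. Its steps to the branched compounds, a 1.3-fold lower number from compound 1 to compound 4 (0.11 log units; within the scatter) and a 1.6-fold lower number from compound 2 to compound 4 (0.20 log units; within the scatter), are also within the scatter, even though the latter is the largest step among the four compounds, so neither the straight chain nor the branched groups separate from the others at this place. No evidence is available that would explain this lack of separation.

As far as these compounds go, what remains open is whether a longer chain, a phenyl ring, a carboxylic acid or an amine carried on the saturated chain carbon bound to an amine nitrogen in a ring would also stay within the scatter. All four compounds share the rest of the core, so they do not show how the number responds to changes anywhere else in the structure.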